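Compound 3 in a cytotoxicity read-out at its limit

The source may report more compounds than this note shows. Statements on the series, on what has been measured and on what is new or still open speak of the compounds shown alone.

Compound 1 `COc1ccc(NC(=O)Nc2cc(C)nc3ccccc23)cc1OC`: > 25000 nM (a limit)
Compound 2 `Cc1cc(NC(=O)Nc2ccc(C(F)(F)F)cc2)c2ccccc2n1`: > 25000 nM (a limit)

Both compounds were tested in an ADME assay on BJ cells (Homo sapiens) for cytotoxicity, with a stated time of 72 h; on this read-out lower numbers stand for an effect already at smaller amounts and higher numbers for an effect only at larger amounts of compound. In this read-out, compound 1 gives > 25000 nM, which is a limit and not a number. Compound 2 likewise gives only a limit, > 25000 nM, and no number. Compound 2 therefore stands with compound 1 at the limit of > 25000 nM in this assay, at which 2 of the 2 values shown sit.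

Compound 3 `COc1ccc(NC(=O)Nc2cc(C)nc3ccccc23)cc1` has not yet been measured. It carries methoxy in place of trifluoromethyl on an aromatic carbon, para to a large group: methoxy in place of trifluoromethyl on an aromatic carbon. Within the data shown here, no step between measured compounds is available as a guide. The expected step of a number no higher from compound 2 to compound 3 (the limit leaves the size open) is estimated to lie within the usual scatter, with no direction favoured. This expectation rests only on compound 2 and its limit of > 25000 nM. For compound 3 the estimated value is 25000 nM, with an expected range from 12000 nM to 50000 nM.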

Compound 3, half-maximal effective concentration: > 25000 nM
Compound 3: no number, only a limit (the forecaster's own chance of this, stated with the estimate: 85%); the middle value lies on the limit itself.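

In this assay, among these compounds, compound 3 gives > 25000 nM, a limit and not a number, so no step from compound 1 or compound 2 to compound 3 can be read. The compounds shown leave open how methoxy, trifluoromethyl and hydrogen compare in this read-out: the limit of > 25000 nM in this assay, at which 3 of the 3 values shown sit.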